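The source may report more compounds than this note shows. Statements on the series, on what has been measured and on what is new or still open speak of the compounds shown alone.

Working notes on the series. The shared core is that of compound 1 `N#Cc1c(Nc2ccc([N+](=O)[O-])cc2)sc2ccccc12`, which in a functional assay on HUVEC cells (Homo sapiens), read by fluorescence and microscopy, with a stated time of 6 h, tested at 250 nM (a higher number here means a weaker effect of the compound at the concentration tested, a lower number a stronger effect), gives 37%. Compound 2 `N#Cc1c(Nc2ccc(N)cc2)sc2ccccc12` carries amino in place of nitro on an aromatic carbon and in this assay gives 51%. Among the compounds with values here, the only step measured so far, a number 14 percentage points higher from compound 1 to compound 2 (beyond the scatter), is that exchange. On the two numbers in hand compound 2 stands highest, with compound 1 the nearest and lower by that same step.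

Compound 3 `N#Cc1c(Nc2ccc(F)cc2)sc2ccccc12` is the next member. It differs from compound 2 in one place: fluoro in place of amino on an aromatic carbon. Within the data shown here, no measured step covers fluoro at that position; the one step that bears on it, a number 14 percentage points higher from compound 1 to compound 2 (beyond the scatter), concerns the same aromatic carbon and was of modest size, so a change of about that size in either direction, or none beyond the scatter, is what the data allow in this assay. Compound 3 is therefore expected to land near the two values already seen, with the step of a number 8 percentage points lower from compound 2 to compound 3 (within the scatter) estimated as small. For compound 3 the estimate is 43%, ranging from 25% to 62%.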

Compound 3, a percentage reported as activity, at one concentration (the size of the read-out at that concentration, not a potency): 58%
Beside the measured number, compound 3's estimate is 15 percentage points below it; measured number inside the range.
By their numbers in this assay, from the lowest: compound 1; then compounds 2 and 3 (each within the scatter of the next).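

Fluoro in place of amino gives a number 7 percentage points higher from compound 2 to compound 3 (within the scatter) in this assay at this aromatic carbon, para to a large group, so the two groups cannot be told apart here, even though amino counts a hydrogen-bond donor and acceptor and fluoro counts neither. Fluoro in place of nitro gives a number 21 percentage points higher from compound 1 to compound 3 (beyond the scatter) in the same assay, which means that compound 1 now stands apart from two different replacements rather than one, with the lowest number and so the strongest effect of the three compounds at the concentration tested. Nothing in hand accounts for this difference between nitro and the other two groups.

As far as these compounds go, whether the separation seen for compound 1 is particular to nitro remains open, and a trifluoromethyl group, a carboxylic acid or a methoxy group at the same aromatic carbon would bear on that question. From the compounds shown here alone, it also remains open whether the close agreement of compound 2 and compound 3 extends to a plain hydrogen, to chloro or to a longer chain at this position.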